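The compounds below may be only part of what the source reports. "The series", "measured", "known", "first", "only" and "open" are said of these compounds alone.

Compound 1 `COc1cc(C(F)(F)F)cc(SC)c1C(=O)NC1(c2ccccc2)CCCN(C)C1`: 24 nM
Compound 2 `COc1ccc(C2(NC(=O)c3c(OC)cc(C(F)(F)F)cc3SC)CCCN(C)C2)cc1`: 170 nM

Of these two measurements in an assay on cells for inhibition of sodium- and chloride-dependent glycine transporter 1 (Homo sapiens) (a higher number here means that more compound is needed for the effect, a lower number that less compound is needed), compound 2 holds the higher number. Among the compounds with values here, its nearest neighbour is compound 1, and the one measured step, a 7.1-fold higher number from compound 1 to compound 2 (0.85 log units; beyond the scatter), separates them; that step is a methoxy group in place of hydrogen on an aromatic carbon.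

Compound 3 `COc1cc(C(F)(F)F)cc(SC)c1C(=O)NC1(c2cccc(Cl)c2)CCCN(C)C1` differs from compound 2 by 3-chlorophenyl in place of 4-methoxyphenyl on a saturated ring carbon. The change does two things at once: the methoxy group that compound 2 carries is gone, and a chlorine now sits on the ring instead. Within the data shown here, only one measured step bears on this, a 7.1-fold higher number from compound 1 to compound 2 (0.85 log units; beyond the scatter), which shows what arrival of that methoxy group cost. Removing it again is expected to undo most of that cost, while nothing measured here tells what the chlorine adds or takes away. Because of a 7.1-fold higher number from compound 1 to compound 2 (0.85 log units; beyond the scatter) the expected step is a 4.3-fold lower number from compound 2 to compound 3 (0.63 log units; beyond the scatter), toward the number of compound 1, with wide uncertainty for the chlorine. Compound 3 is estimated at 40 nM in this assay, within a range of 10 nM to 160 nM.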

Compound 3, half-maximal effective concentration: 25 nM
Compound 3: the middle estimate sits 1.6-fold (0.20 log units) above what was measured; measured number inside the range.
By their numbers in this assay, from the lowest: compounds 1 and 3 (each within the scatter of the next); then compound 2.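

Replacing 4-methoxyphenyl with 3-chlorophenyl on this saturated ring carbon gives (a 6.8-fold lower number from compound 2 to compound 3 (0.83 log units; beyond the scatter)), so the penalty seen with compound 2 is absent from compound 3. Compared with the unsubstituted phenyl of compound 1, the chlorine gives (a 1.0-fold higher number from compound 1 to compound 3 (0.02 log units; within the scatter)), which lies within the scatter, so in this assay this aromatic ring carries a chlorine with no readable change in the number, whereas the methoxy group in compound 2 gave a clear step. Substitution on this ring therefore does not always cost activity here, although no measurement shown gives a cause for the difference between these two results.

On these data alone, the step from compound 2 to compound 3 changes both the group and its place on the aromatic ring, so it remains open whether the higher number of compound 2 belongs to the methoxy group itself or to where it sits, a question that 3-methoxyphenyl and 4-chlorophenyl would address directly. It is also open how this ring position would respond to a different kind of group, such as an amine or a carboxylic acid, since chlorine and methoxy are the only substituents on this ring among the compounds shown.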